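A few compounds are considered here, and "the series" means these few. Any claim that something is new, unique, unknown or untested is made for them only; others in the source may bear on it.

In a functional assay on Jurkat cells (Homo sapiens) for antiproliferative activity, read by WST assay, with a stated time of 72 h (on this read-out lower numbers stand for stronger inhibition and higher numbers for weaker inhibition), compound 1 `Oc1ccc2[nH]c(-c3nc(-c4ccccc4)no3)cc2c1` gives 26900 nM, and compound 2 `Fc1ccc2[nH]c(-c3nc(-c4ccccc4)no3)cc2c1` gives 33800 nM. Within the data shown here, the only step between measured compounds, a 1.3-fold higher number from compound 1 to compound 2 (0.10 log units; within the scatter), is the change fluoro in place of hydroxy on an aromatic carbon. Compound 2 thus holds the highest of the two numbers, with compound 1 as its nearest neighbour and within the scatter of it.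

Compound 3 `Fc1ccc2[nH]c(-c3nc(-c4ccc(Cl)cc4)no3)cc2c1` differs from compound 2 by chloro in place of hydrogen on an aromatic carbon. Among the measured compounds shown here, no measured step touches the phenyl ring: the single step in this set concerns the other end of the shared core and says nothing about a chloro on the phenyl. There is therefore no basis for expecting a step beyond the scatter in this assay for compound 3, and the estimate stays close to the number of compound 2. Compound 3 is expected at 22000 nM in this assay, with a range from 8000 nM to 60000 nM, which means an expected step of a 1.5-fold lower number from compound 2 to compound 3 (0.19 log units; within the scatter).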

Compound 3, half-maximal inhibitory concentration: > 50000 nM
Compound 3 was reported as a limit; the forecaster's own chance of this, stated with the estimate: 10%; at least 2.2-fold (0.35 log units) between middle value and limit.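

In this assay compound 3 gives > 50000 nM, which is a limit of the assay and not a number. Among these compounds, this is the first step on the phenyl end of the series, an at least 1.4-fold higher number from compound 2 to compound 3 (0.17 log units; that floor lies within the scatter): 4-chlorophenyl in place of phenyl gives no lower number, although the floor of the step does not separate the two compounds. The true size of the step stays unknown, and this is the only reading in the series that sits at the limit: the limit of > 50000 nM in this assay, at which 1 of the 3 values shown sits.

From the compounds shown here alone, it remains open whether another group at the same place on the phenyl ring, such as methoxy, an amine or a carboxylic acid, would give a lower number than compound 2 does. Also open, going by these compounds, is whether chloro has the same outcome when paired with the hydroxy of compound 1.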